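The compounds below may be only part of what the source reports. "The series", "measured", "known", "first", "only" and "open" are said of these compounds alone.

The set opens with two measured compounds that share one core. Compound 1 `Cn1c(=O)c2nc(-c3ccc(C(F)(F)F)cc3)[nH]c2n(C)c1=O` carries a hydrogen on the imidazole nitrogen, and in an assay for binding affinity to adenosine receptor A1 (Rattus norvegicus), read by radioligand binding (on this read-out lower numbers stand for stronger inhibition and higher numbers for weaker inhibition), compound 1 gives 150 nM. Compound 2 `Cn1c(=O)c2c(nc(-c3ccc(C(F)(F)F)cc3)n2C)n(C)c1=O` differs by carrying a methyl on that imidazole nitrogen, and in this assay compound 2 gives 17000 nM. Of the two numbers, compound 2 has the highest, its nearest neighbour being compound 1, whose number is far lower, well beyond the usual scatter; the two compounds therefore stand far apart on the read-out.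

Compound 3 `C=CCn1c(=O)c2c(nc(-c3ccc(C(F)(F)F)cc3)n2C)n(C)c1=O` has not yet been measured in this assay. It differs from compound 2 by vinyl in place of hydrogen on a saturated chain carbon bound to an aromatic nitrogen, so the methyl on the ring nitrogen flanked by the two carbonyls becomes an allyl. For the measured compounds named here, no step between measured compounds speaks to this change, so its size cannot be read off the data. For compound 3 a moderate shift towards a lower number is expected, a 3.4-fold lower number from compound 2 to compound 3 (0.53 log units; beyond the scatter), and compound 3 is estimated at 5000 nM with a range from 1500 nM to 17000 nM.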

Compound 3, inhibition constant: 5700 nM
Compound 3: middle estimate off by 1.1-fold (0.06 log units), on the low side; low and high end bracket the measured number.
By their numbers in this assay, from the lowest: compound 1; then compound 3; then compound 2.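

For the compounds shown here, the first reading at this position comes from vinyl in place of hydrogen on a saturated chain carbon bound to an aromatic nitrogen, the same difference as methyl to allyl, and in this assay it gives a 3.0-fold lower number from compound 2 to compound 3 (0.47 log units; beyond the scatter) as a modest step. Going by these compounds alone, the earlier compounds varied at another place only, so this is the first sign that the position responds at all, and that adding 2 carbon atoms here moves the number towards stronger inhibition rather than weaker, with compound 3 at 5700 nM on this read-out. No measurement at hand explains why the step has this direction or this size.

On these data alone, what a saturated propyl chain, a benzyl group or a longer chain would do at this position stays open, and with it the question of whether the double bond or simply the added carbons carry the step. Also open, as far as these compounds go, is whether the same change from methyl to allyl would give a step of similar size on compound 1, which has a hydrogen where compound 2 and compound 3 have a methyl on the imidazole nitrogen.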